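The source may report more compounds than this note shows. Statements on the series, on what has been measured and on what is new or still open speak of the compounds shown alone.

Measured so far, both in a functional assay on Jurkat cells (Homo sapiens) for cytotoxicity, read by luminescence and CellTiter-Glo, with a stated time of 3 days (on this read-out lower numbers stand for stronger inhibition and higher numbers for weaker inhibition), on the same cells
Compound 1 `O=C(Nc1cc(C(F)(F)F)cc(C(F)(F)F)c1)c1cc(Br)c(F)cc1O` gives 700 nM
Compound 2 `O=C(Nc1ccc(Cl)cc1Cl)c1ccc2cccnc2c1O` gives 430 nM

Within the data shown here, with only two numbers available, compound 2 stands within the usual scatter of compound 1, so the two cannot be told apart. Compound 3 `O=C(Nc1ccc(Cl)cc1)c1ccc2cccnc2c1O` is still unmeasured. It differs from compound 2 in one place (hydrogen in place of chloro on an aromatic carbon) with hydrogen in place of chloro on an aromatic carbon of a six-membered aromatic ring of carbon only, ortho to a large group and meta to a chloro group.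

Among the measured compounds shown here, no measured pair shows what such a swap does in this assay and any expectation here is therefore rough. For the measured compounds named here, the only guide is that compound 1 at 700 nM sits within the scatter of compound 2 although the two structures look quite different. A single swap is thus expected to move the number only a little. The expected 1.4-fold higher number from compound 2 to compound 3 (0.14 log units; within the scatter) is small, toward a higher number and so weaker inhibition, and it may well stay within the scatter. Compound 3 is estimated at 600 nM with 220 nM to 1600 nM as the expected range.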

Compound 3, half-maximal inhibitory concentration: 510 nM
The estimate for compound 3 lay 1.2-fold (0.07 log units) above the measured number, within the range that was stated.
By their numbers in this assay, from the lowest: compounds 2, 3 and 1 (each within the scatter of the next).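

In this assay, replacing the chloro group with hydrogen gives a 1.2-fold higher number from compound 2 to compound 3 (0.07 log units; within the scatter), so the two numbers cannot be told apart. Among these compounds, this is the first direct test of a single change in this set, and it shows that on this core, at the place ortho to a large group and meta to a chloro group, a chloro group and a hydrogen give the same result within the scatter; cytotoxicity on these cells therefore does not depend on having the chloro group at this place. Nothing available explains this result or shows how either compound acts on the cells.

Hydrogen and chloro are the only two groups seen at this place, so it remains open whether a methoxy group, an amine or a carboxylic acid there would also leave the number in the same range. Going by these compounds, the role of the chloro group that compound 2 and compound 3 share also remains open, as does that of the ring hydroxyl group, since neither is varied in this pair.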